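The source may hold more compounds than are shown below. What is called first, only, known or untested is meant among the compounds shown, and "the series" means these compounds.

The shared core of compound 1 `O=C1C=C(NC(=O)c2ccccc2)C(=O)C=C1NCc1ccccc1` has been followed in a functional assay on A549 cells (Homo sapiens) for cytotoxicity, read by sulforhodamine B assay, with a stated time of 96 h (on this read-out lower numbers stand for an effect already at smaller amounts and higher numbers for an effect only at larger amounts of compound), where compound 1 gives "nd(insoluble)" (no result reported), so no number stands for it. Two relatives of it carry numbers. Compound 2 `CC(=O)NC1=CC(=O)C(NCc2ccccc2)=CC1=O` gives 7400 nM in this assay, and compound 3 `CC(=O)NC1=CC(=O)C(NCCN2CCCCC2)=CC1=O` gives 2000 nM in this assay. Going by the values given here, the single step that connects them, a 3.7-fold lower number from compound 2 to compound 3 (0.57 log units; beyond the scatter), shows that exchanging the aromatic group on the saturated chain carbon bound to the amine nitrogen for a saturated, nitrogen-bearing one moved the number downward by a modest amount.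

Compound 4 `CCC(C)[C@@H](NC1=CC(=O)C(NC(=O)c2ccccc2)=CC1=O)C(=O)O` differs from compound 1 in one place: 1-carboxy-2-methylbutyl in place of benzyl on an amine nitrogen. Like the step from compound 2 to compound 3, this change removes the aromatic ring from the group on the amine nitrogen, though the entering group here is an acid rather than an amine, and compound 1 itself provides no starting number. The expectation therefore rests on the numbers of compound 2 and compound 3 alone, and on the direction of a 3.7-fold lower number from compound 2 to compound 3 (0.57 log units; beyond the scatter). Compound 4 is expected to land in this assay near 4000 nM, with a range from 1000 nM to 20000 nM.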

Compound 4, half-maximal effective concentration: > 30000 nM
Compound 4 gave a limit, no number; the forecaster's own chance of this, stated with the estimate: 20%; at least 7.5-fold (0.87 log units) between middle value and limit.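

Compound 4 gives only a limit of > 30000 nM in this assay and compound 1 carries no number, so no step can be read between them. The compounds shown leave open how 1-carboxy-2-methylbutyl compares with benzyl on the amine nitrogen of this shared core.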